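Aryl amide in place of benzyl amide: expected cytotoxicity

The source may report more compounds than this note shows. Statements on the series, on what has been measured and on what is new or still open speak of the compounds shown alone.

Compound 3 `C=CC1=C(C(=O)NCc2ccccc2F)C(c2ccc(OC)cc2)OC1` stands at the top of what the assay can report: in a functional assay on HeLa cells (Homo sapiens) for cytotoxicity, read by MTT assay, with a stated time of 24 h (a lower number here means a stronger inhibitor, a higher number a weaker inhibitor), compound 3 gives > 100000 nM, which is a limit of the assay and not a number. Compound 1 `C=CC1=C(C(=O)NC(C)(C)C)C(c2ccc(OC)cc2)OC1` in this assay gives > 100000 nM, also a limit. Compound 2 `C=CC1=C(C(=O)NCCCCC)C(c2ccc(OC)cc2)OC1` in this assay gives > 100000 nM, again a limit. Compound 4 `C=CC1=C(C(=O)Nc2ccccc2OC)C(c2ccc(OC)cc2)OC1` differs from compound 3 by 2-methoxyphenyl in place of 2-fluorobenzyl on an amide-type nitrogen. The measured steps a step that the two limits leave unreadable from compound 1 to compound 2, a step that the two limits leave unreadable from compound 1 to compound 3 and a step that the two limits leave unreadable from compound 2 to compound 3 all rest on (the limit of > 100000 nM in this assay, at which 3 of the 3 values shown sit), so none of them shows how far a change on the amide-type nitrogen can move the read-out. Compound 4 is therefore expected to give 100000 nM, between 30000 nM and 300000 nM, most probably once more as a limit. The expected step is a number no higher from compound 3 to compound 4 (the limit leaves the size open).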

Compound 4, half-maximal inhibitory concentration: > 100000 nM
Compound 4: only a limit was reported (the forecaster's own chance of this, stated with the estimate: 80%); the middle value sits exactly at the limit.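

In this assay, no step can be read among compound 1, compound 2, compound 3 and compound 4, because all four rest on one limit: the limit of > 100000 nM in this assay, at which 4 of the 4 values shown sit.

The compounds shown leave open whether any change on the amide-type nitrogen can move the read-out, and how far.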